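Trifluoromethyl in Place of Methyl: An Expected Step

This account rests on a few compounds, and the source may have more. Where it says the series, first, only, none or still open, it means among the compounds named here.

Measured compounds:
compound 1, `Nc1cc(N2CCN(c3cccc(Cl)c3)CC2)ncn1`: > 2000 nM
compound 2, `Cc1ccc(Cl)cc1N1CCN(c2ncnc3[nH]nc(C)c23)CC1`: 9 nM

Going by the values given here, in an assay for inhibition of ribosomal protein S6 kinase beta-1 variant D18H,T412E (Homo sapiens), read by a luciferase reporter and chemiluminescence, with a stated time of 3 h (a lower number here means a stronger inhibitor, a higher number a weaker inhibitor), compound 2 gives 9 nM, the only value that comes out as a number. Compound 1 reaches only a limit in this assay, > 2000 nM. That result is the limit of > 2000 nM in this assay, at which 1 of the 2 values shown sits. Among the compounds with values here, the two compounds differ in several places, so their values show only that compound 2 inhibits and compound 1 does not reach a number.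

Compound 3, `Cc1ccc(Cl)cc1N1CCN(c2ncnc3[nH]nc(C(F)(F)F)c23)CC1`, has yet to be measured. It differs from compound 2 by trifluoromethyl in place of methyl on an aromatic carbon. Within the data shown here, no step between measured compounds bears on this change, so its size is open. For compound 3 the expected step is a 1.7-fold higher number from compound 2 to compound 3 (0.22 log units; within the scatter) in this assay, within the usual scatter or a small loss. Compound 3 is estimated at 15 nM, between 4 nM and 60 nM.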

Compound 3, half-maximal inhibitory concentration: 29 nM
Estimate against measurement, compound 3: 1.9-fold (0.29 log units) below; measured number inside the range.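

In this assay, the aromatic carbon of the five-membered ring accepts trifluoromethyl without loss of a measurable value: compound 3 gives 29 nM. Going by these compounds alone, the change is still not neutral, and it provides the first single-place comparison: a 3.2-fold higher number from compound 2 to compound 3 (0.51 log units; beyond the scatter). Nothing measured here on the compounds accounts for this difference.

The compounds shown cover only methyl and trifluoromethyl at this carbon, so it remains open how an ethyl group, an amine or a methoxy group would read there. On these data alone, it also remains open whether the same exchange would produce a step of similar size on a different core, as this single pair of compounds offers no second case for comparison.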